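The source may hold more compounds than are shown below. What is called first, only, known or untested is meant among the compounds shown, and "the series" means these compounds.

Among the compounds with values here, compound 2 `Cc1cc(O)cc(-c2nn(CC#N)cc2-c2ccnc(-c3ccc(Oc4ccccc4)cc3)c2)c1` and compound 1 `COc1cc(C)cc(-c2nn(CC#N)cc2-c2ccc(-c3cccc(C(C)=O)c3)nc2)c1` share a common core and differ at two places, so no single step connects them. In a functional assay on HCT-116 cells (Homo sapiens) for cytotoxicity, read by sulforhodamine B assay, with a stated time of 48 h, tested at 0.01 uM (on this read-out higher numbers stand for a weaker effect at the one concentration tested and lower numbers for a stronger effect), compound 1 gives 93%, and in this assay compound 2 gives 94%, the higher of the two numbers, with the gap to the value of compound 1 lying within the scatter of the measurement. Both compounds therefore show only a weak effect at the one concentration tested.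

Compound 3 `Cc1cc(O)cc(-c2nn(CC#N)cc2-c2ccnc(-c3ccc(N(C)C)cc3)c2)c1` has not yet been measured in this assay. It differs from compound 2 by dimethylamino in place of phenoxy on an aromatic carbon. Within the data shown here, no measured pair in this set isolates that kind of change, so there is no measured step to lean on. Given that compound 2 sits at 94%, near the top of the read-out scale, the step is expected to be small and not beyond the scatter in either direction: the estimated change from compound 2 to compound 3 is a number 2 percentage points lower from compound 2 to compound 3 (within the scatter). Compound 3 is accordingly expected to give about 92%, with a range from 80% to 103%.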

Compound 3, a percentage reported as activity, at one concentration (the size of the read-out at that concentration, not a potency): 98%
Estimate against measurement, compound 3: 6 percentage points below; the measured number falls inside the stated range.
By their numbers in this assay, from the lowest: compounds 1, 2 and 3 (each within the scatter of the next).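

Within the data shown here, putting dimethylamino in place of phenoxy on an aromatic carbon, para to a large group, gives a number 4 percentage points higher from compound 2 to compound 3 (within the scatter) in this assay and so provides the first step in this set that isolates a single change. The ring of phenoxy leaves with this change and a group with fewer heavy atoms enters, yet the read-out does not move beyond the scatter, so at this position the two groups cannot be told apart at the one concentration tested. Both compounds of the pair show only a weak effect, and no measurement shown offers a reason for the result.

From the compounds shown here alone, it remains open whether a carboxylic acid or a longer chain ending in an amine on this same carbon would give a stronger effect at that concentration, or would likewise leave the read-out within the scatter. Going by these compounds, it also remains open whether the same exchange of phenoxy for dimethylamino would read alike on the core of compound 1.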